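This account rests on a few compounds, and the source may have more. Where it says the series, first, only, none or still open, it means among the compounds named here.

Working notes on the series.

The shared core is carried by compound 1 `CC1=CCC2C(CC[C@@]2(C)O)C(C)(C)C1CC[C@@H]1[C@@]2(C)CC[C@@H](O)C(C)(C)O[C@@H]2CC[C@]1(C)O` and by compound 2 `CC1=CC[C@H]2[C@@H]1CC=C(C)[C@@H](CCC1=C(C)CC[C@@H]3OC(C)(C)[C@@H](O)CC[C@@]13C)C2(C)C`. In a functional assay on MDA-MB-231 cells (Homo sapiens) for antiproliferative activity, read by MTT assay, with a stated time of 72 h (a lower number here means a stronger inhibitor, a higher number a weaker inhibitor), compound 1 reaches only the limit of the assay, > 50000 nM. Compound 2 likewise gives only a limit in this assay, > 50000 nM. Among the measured compounds shown here, compound 3 `CC1=CC[C@H]2[C@H](CC[C@]2(C)O)C(C)(C)[C@@H]1CC[C@H]1[C@]2(C)CC[C@H](OC(=O)c3ccc(Cl)cc3)C(C)(C)O[C@H]2CC[C@@]1(C)O` adds a ((4-chlorophenyl)carbonyl)oxy group and is the one member with a measured number: in this assay compound 3 gives 10300 nM, which places it as the only compound of the three with a value inside the measurable range, the other two sitting at the limit of > 50000 nM in this assay, at which 2 of the 3 values shown sit.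

Compound 4 `CC1=CC[C@H]2[C@H](CC[C@]2(C)O)C(C)(C)[C@@H]1CC[C@H]1[C@]2(C)CC[C@H](OC(=O)c3ccccc3[N+](=O)[O-])C(C)(C)O[C@H]2CC[C@@]1(C)O` is not yet measured. It differs from compound 3 in one place, (2-nitrophenyl in place of 4-chlorophenyl on a carbonyl carbon), the ester oxygen and the rest of the core staying as they are.

For the measured compounds named here, no measured step tracks this kind of exchange on the carbonyl carbon, so there is no basis for expecting a shift beyond the usual scatter in either direction. The working expectation is that compound 4 lands close to compound 3, with the step from compound 3 to compound 4 estimated as a 1.2-fold higher number from compound 3 to compound 4 (0.07 log units; within the scatter). In this assay compound 4 is therefore expected to give about 12000 nM, within a range of 4000 nM to 40000 nM.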

Compound 4, half-maximal inhibitory concentration: 38700 nM
Beside the measured number, compound 4's estimate is 3.2-fold (0.51 log units) below it, and the stated range covers the measured number.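

Among the compounds shown here, the exchange of 4-chlorophenyl for 2-nitrophenyl on a carbonyl carbon gives, in this assay, a 3.8-fold higher number from compound 3 to compound 4 (0.57 log units; beyond the scatter), which is the first step that can be read at this position. The number therefore responds to the group carried on the ester, and here the response is a modest move toward a weaker inhibitor, with the ester oxygen and the rest of the core unchanged. The series now holds two measured numbers that differ in one place, and the other values are limits rather than numbers: the limit of > 50000 nM in this assay, at which 2 of the 4 values shown sit.

As far as these compounds go, whether this step follows from the nitro group, from the loss of the chlorine or from where each group sits on the phenyl ring stays open, as compound 3 and compound 4 differ in all of these at once. Also open, from the compounds shown here alone, is how a plain phenyl, an aminophenyl or a longer alkyl chain on the same carbonyl carbon would read in this assay, and whether any group there would improve on compound 3 at 10300 nM.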